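Swapping a Thiazole for a Cyanophenyl on the Core

The compounds below may be only part of what the source reports. "The series", "measured", "known", "first", "only" and "open" are said of these compounds alone.

Of the compounds shown here, three that share one core have been tested in a functional assay on CHO-K1 cells for antagonist activity at adenosine receptor A1 (Homo sapiens), read by a beta-galactosidase reporter and cAMP accumulation, with stated times of 15 min and 6 h; on this read-out lower numbers stand for stronger inhibition and higher numbers for weaker inhibition. Compound 1 `Cc1ccc(-c2nc(N)c3cc(Cc4ccccc4Cl)sc3n2)o1` gives 26.1 nM in this assay. Compound 2 `Cc1csc(-c2nc(N)c3cc(C(C)c4ccccc4)sc3n2)n1` gives 1420 nM. For compound 3 `Cc1csc(-c2nc(N)c3cc(C4(c5ccccc5)CC4)sc3n2)n1` the assay reported only a limit, > 610 nM, so compound 3 stands at the limit of > 610 nM in this assay, at which 1 of the 3 values shown sits, rather than at a number. Compound 4 `N#Cc1cccc(-c2nc(N)c3cc(C4(c5ccccc5)CC4)sc3n2)c1` differs from compound 3 in one place: 3-cyanophenyl in place of 4-methyl-1,3-thiazol-2-yl on an aromatic carbon. For the measured compounds named here, no measured pair shows this change, so its effect is unknown. The expected step from compound 3 to compound 4 is an at least 1.2-fold lower number from compound 3 to compound 4 (0.08 log units; that floor lies within the scatter), with the direction uncertain. Compound 4 is therefore estimated at 500 nM, with a range from 100 nM to 3000 nM.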

Compound 4, inhibition constant: > 610 nM
Compound 4 was reported as a limit; the forecaster's own chance of this, stated with the estimate: 30%; at least 1.2-fold (0.08 log units) between middle value and limit.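

In this assay compound 3 and compound 4 are both reported only as limits, so no step between them can be read: the limit of > 610 nM in this assay, at which 2 of the 4 values shown sit.

As far as these compounds go, whether 3-cyanophenyl or 4-methyl-1,3-thiazol-2-yl gives the stronger inhibition on the shared core stays open.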